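This account rests on a few compounds, and the source may have more. Where it says the series, first, only, none or still open, it means among the compounds named here.

Measured compounds in an ADME assay on HEL cells (Homo sapiens) for cytotoxicity; a lower number here means that less compound is tolerated, a higher number that more compound is tolerated:
Compound 1 `CC(C)(C)c1ccc(OCCCCCn2ccc(=O)[nH]c2=O)cc1`: 40000 nM
Compound 2 `Nc1ccc(OCCCCCn2ccc(=O)[nH]c2=O)cc1`: > 100000 nM
Compound 3 `O=c1ccn(CCCCCOc2ccccc2)c(=O)[nH]1`: > 100000 nM

Within the data shown here, compound 1 is the only member of the set with a numerical read-out. For compound 2 the value is a limit of the assay, not a number. For compound 3 the value likewise is a limit of the assay. Compound 3 therefore stands at the upper edge of what this assay reports, and it shares that position with one other compound (the limit of > 100000 nM in this assay, at which 2 of the 3 values shown sit).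

The next compound, compound 4 `Cc1ccc(OCCCCCn2ccc(=O)[nH]c2=O)cc1`, differs from compound 3 by methyl in place of hydrogen on an aromatic carbon.

Among the measured compounds shown here, two measured steps bear on this change. Removing the tert-butyl group gave an at least 2.5-fold higher number from compound 1 to compound 3 (0.39 log units; beyond the scatter), and replacing it by amino gave an at least 2.5-fold higher number from compound 1 to compound 2 (0.39 log units; beyond the scatter). The step between the two limits, a step that the two limits leave unreadable from compound 2 to compound 3, cannot be sized. The change from compound 3 to compound 4 runs in the opposite sense to the step from compound 1 to compound 3, but the group entering is methyl, far smaller than the tert-butyl that left. The expectation is therefore a value at or just under the limit, with a step in this assay of an at least 1.1-fold lower number from compound 3 to compound 4 (0.04 log units; that floor lies within the scatter) expected. Compound 4 is estimated at 90000 nM, within 40000 nM to 200000 nM.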

Compound 4, half-maximal cytotoxic concentration: > 100000 nM
Compound 4 was reported as a limit (the forecaster's own chance of this, stated with the estimate: 50%); middle value at least 1.1-fold (0.04 log units) from the limit.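

In this assay compound 4 gives > 100000 nM, which is a limit of the assay and not a number. Replacing tert-butyl by methyl on this aromatic carbon, para to a large group, gave an at least 2.5-fold higher number from compound 1 to compound 4 (0.39 log units; beyond the scatter), so a carbon substituent at this place does not in itself bring the read-out within the measurable range, and of these compounds only the tert-butyl one, compound 1, gives a number. The steps among compound 2, compound 3 and compound 4 cannot be read, and the hydrogen, amino and methyl compounds now sit together at the top of the reported range: the limit of > 100000 nM in this assay, at which 3 of the 4 values shown sit.

Where, between methyl and tert-butyl, the read-out first drops under the limit stays open; an ethyl or isopropyl group on the same carbon would help to locate it. Also open, as far as these compounds go, is whether the limit holds for a carboxylic acid at this place, or for a longer linking chain with any of these groups.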